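The source may report more compounds than this note shows. Statements on the series, on what has been measured and on what is new or still open speak of the compounds shown alone.

Working notes on the series.

Among the measured compounds shown here, compound 3 `CN(C)C1(Cc2ccccc2)CCN(c2cc(C(F)(F)F)ccc2CNC(=O)Nc2ccc3cccnc3c2)CC1` sits second highest of the three numbers so far in an assay on CHO cells for displacement of a labelled ligand from transient receptor potential cation channel subfamily V member 1 (Homo sapiens), read by scintillation counting, with a stated time of 60 min; a lower number here means a stronger inhibitor, a higher number a weaker inhibitor: compound 3 gives 14.1 nM. Its nearest neighbour is compound 2 `CN(C)C1(Cc2ccccc2)CCN(c2cc(C(F)(F)F)ccc2CNC(=O)Nc2cccc3c(=O)[nH]ccc23)CC1`, which in this assay gives 111 nM, the step being a 7.9-fold lower number from compound 2 to compound 3 (0.90 log units; beyond the scatter). Furthest away is compound 1 `CN(C)C1(Cc2ccccc2)CCN(c2cc(C(F)(F)F)ccc2CNC(=O)Nc2cccc3[nH]c(=O)ccc23)CC1`, which in this assay gives 1.67 nM, with an 8.4-fold higher number from compound 1 to compound 3 (0.93 log units; beyond the scatter). The remaining pair gives a 66-fold higher number from compound 1 to compound 2 (1.82 log units; beyond the scatter).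

Compound 4 `CN(C)C1(Cc2ccccc2)CCN(c2cc(C(F)(F)F)ccc2CNC(=O)Nc2cccc3ncccc23)CC1` differs from compound 3 by quinolin-5-yl in place of quinolin-7-yl on an amide-type nitrogen. For the measured compounds named here, both measured steps that touch compound 3 swap a ring system carrying a carbonyl and a ring nitrogen-hydrogen for one carrying only a ring nitrogen, so neither moves the attachment point of an otherwise unchanged bicycle, and no measured step bears directly on the present change. The two quinolinone isomers in compound 1 and compound 2, joined through the same kind of nitrogen, differ by a 66-fold higher number from compound 1 to compound 2 (1.82 log units; beyond the scatter), which shows that rearranging a bicycle can shift this assay considerably, though in an unknown direction here.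

Going by the values given here, with no direct precedent, compound 4 is expected to land close to compound 3, the step of a 1.4-fold lower number from compound 3 to compound 4 (0.15 log units; within the scatter) carrying wide uncertainty. The estimate for compound 4 in this assay is 10 nM, with a range from 2.5 nM to 40 nM.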

Compound 4, inhibition constant: 10.8 nM
Compound 4: middle estimate off by 1.1-fold (0.03 log units), on the low side; the range from low to high includes it.
By their numbers in this assay, from the lowest: compound 1; then compounds 4 and 3 (each within the scatter of the next); then compound 2.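

Moving the attachment from quinolin-7-yl to quinolin-5-yl on the amide-type nitrogen gives, in this assay, a 1.3-fold lower number from compound 3 to compound 4 (0.12 log units; within the scatter), so this change has no resolved effect on the read-out, whereas rearranging the carbonyl-bearing bicycle gives a 66-fold higher number from compound 1 to compound 2 (1.82 log units; beyond the scatter). With a 10-fold lower number from compound 2 to compound 4 (1.01 log units; beyond the scatter) and a 6.5-fold higher number from compound 1 to compound 4 (0.81 log units; beyond the scatter), compound 4 joins compound 3 in the interval between the two carbonyl-bearing compounds, with both of those steps beyond the scatter, so neither quinoline attachment reproduces the value of compound 1 or that of compound 2. No evidence is available that explains either the flat quinoline pair or the wide separation of the carbonyl-bearing pair.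

The two quinolines show only that these two attachment points cannot be told apart, and they leave open whether the ring nitrogen contributes at all, a question that a naphthyl group in the same place would address. Going by these compounds, it also remains open whether the gap between compound 1 and the quinolines depends on the carbonyl, on the ring nitrogen-hydrogen or on both, which an indole or a methylated ring nitrogen in the bicycle of compound 1 could begin to separate.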